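Swapping an Ester for a Sulfonic Acid on the Aryl Amide

The compounds below may be only part of what the source reports. "The series", "measured", "known", "first", "only" and "open" are said of these compounds alone.

Measured so far, in a functional assay on CLL cells (Homo sapiens) for cytotoxicity, read by MTT assay, with a stated time of 48 h; on this read-out lower numbers stand for an effect already at smaller amounts and higher numbers for an effect only at larger amounts of compound:
- compound 1 `C=C(CC)C(=O)c1ccc(OCC(=O)Nc2ccc3c(C)cc(=O)oc3c2)c(Cl)c1Cl` gives 2800 nM
- compound 2 `C=C(CC)C(=O)c1ccc(OCC(=O)Nc2ccc(C(=O)OC)cc2)c(Cl)c1Cl` gives 4100 nM
- compound 3 `C=C(CC)C(=O)c1ccc(OCC(=O)Nc2ccc(C(=O)O)cn2)c(Cl)c1Cl` gives 14900 nM

All three share a common core and differ only in the aromatic group attached to the amide nitrogen. On the numbers shown, compound 2 sits second highest of the three. Its value lies within the usual scatter of that of compound 1, so the two cannot be told apart. Among the compounds with values here, compound 3 gives a higher number than compound 2, a difference beyond the scatter; compound 3 differs from compound 2 in more than one place, however, so no single step between measured compounds can be read off.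

Compound 4 `C=C(CC)C(=O)c1ccc(OCC(=O)Nc2ccc(S(=O)(=O)O)cc2)c(Cl)c1Cl` is the next compound, not yet measured. It arises from compound 2 by one change: sulfo in place of methoxycarbonyl on an aromatic carbon. The sulfo group brings a hydrogen-bond donor where the methoxycarbonyl had none. Within the data shown here, with no measured single step to lean on, the only guide is that compound 3, which also carries an acidic group, gives 14900 nM, a weaker effect than compound 2.

The expectation for the step from compound 2 to compound 4 is therefore a modest rise in the number, a 2.0-fold higher number from compound 2 to compound 4 (0.29 log units; within the scatter), possibly no larger than the scatter. Compound 4 is estimated at 8000 nM, with a range from 3000 nM to 25000 nM.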

Compound 4, half-maximal effective concentration: > 25000 nM
Compound 4 gave a limit, no number; the forecaster's own chance of this, stated with the estimate: 15%; middle value at least 3.1-fold (0.49 log units) away from the limit.
By their numbers in this assay, from the lowest: compounds 1 and 2 (each within the scatter of the next); then compound 3. At a limit, above all of these: compound 4.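

In this assay, within the data shown here, sulfo in place of methoxycarbonyl on this aromatic carbon, para to a large group, gives the first single change that can be read: an at least 6.0-fold higher number from compound 2 to compound 4 (0.78 log units; beyond the scatter). Compound 4 gave a limit of the assay and not a number, so the step has a lower bound but no known full size: the limit of > 25000 nM in this assay, at which 1 of the 4 values shown sits.

The two groups match in heavy-atom count and in hydrogen-bond acceptors, and neither contains a ring, yet they differ in the sulfur that replaces carbon, in the double bonds outside aromatic rings and in the hydrogen-bond donor that sulfo brings, so this position clearly does not accept every group of that size equally, although this single pair cannot show which of those differences matters.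

Still open, going by these compounds, is how a sulfonamide or an amine at this same place on the ring would read, which could help to separate the effect of the hydrogen-bond donor from that of the rest of the group. On these data alone, it also remains open whether a smaller change at this position would keep the number close to that of compound 2, at 4100 nM.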